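Amide variation at the carbonyl carbon of the shared core

The source may hold more compounds than are shown below. What is called first, only, known or untested is meant among the compounds shown, and "the series" means these compounds.

Values in an assay on HL-60 cells for agonist activity at vitamin D3 receptor (Homo sapiens), read by microscopy, with a stated time of 96 h; a lower number here means that less compound is needed, a higher number that more compound is needed for the effect:
compound 1 `CCn1c(C(=O)NCCN(C)C)ccc1C(CC)(CC)c1ccc(OCC(=O)C(C)(C)C)c(C)c1`: 77 nM
compound 2 `CCn1c(C(=O)NCCCN(C)C)ccc1C(CC)(CC)c1ccc(OCC(=O)C(C)(C)C)c(C)c1`: 96 nM
compound 3 `CCn1c(C(=O)N(CCC#N)CCC#N)ccc1C(CC)(CC)c1ccc(OCC(=O)C(C)(C)C)c(C)c1`: 870 nM

Compound 3 stands highest of the three numbers in this assay; its nearest neighbour is compound 2 and its furthest compound 1, both beyond the scatter. The step of a 1.2-fold higher number from compound 1 to compound 2 (0.10 log units; within the scatter) is within the scatter, whereas an 11-fold higher number from compound 1 to compound 3 (1.05 log units; beyond the scatter) and a 9.1-fold higher number from compound 2 to compound 3 (0.96 log units; beyond the scatter) are not.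

Compound 4 `CC[C@@H](C)[C@H](NC(=O)c1ccc(C(CC)(CC)c2ccc(OCC(=O)C(C)(C)C)c(C)c2)n1CC)C(=O)O` differs from compound 3 by a group of 9 heavy atoms (6 carbon, 1 nitrogen, 2 oxygen; no ring) in place of a group of 9 heavy atoms (6 carbon, 3 nitrogen; no ring), on a carbonyl carbon. For the measured compounds named here, the only measured steps that touch this carbonyl carbon are those into compound 3, and both record that replacing a group with a dimethylamino-bearing chain by the bis-nitrile group raised the number substantially. Compound 4 now removes that bis-nitrile group again, but what enters is not the dimethylamino-bearing chain of compound 1 or compound 2, so a full return to their values is not assured. A decrease beyond the scatter is expected, of uncertain extent. Compound 4 is therefore estimated at 200 nM in this assay, with a range of 60 nM to 700 nM, which corresponds to an expected step of a 4.4-fold lower number from compound 3 to compound 4 (0.64 log units; beyond the scatter).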

Compound 4, half-maximal effective concentration: 10 nM
Beside the measured number, compound 4's estimate is 20-fold (1.30 log units) above it, and the stated range ends above it.
By their numbers in this assay, from the lowest: compound 4; then compounds 1 and 2 (each within the scatter of the next); then compound 3.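

In this assay, for the compounds shown here, the earlier compounds showed this carbonyl carbon only as a place where the number rises, whereas the change to (1-carboxy-2-methylbutyl)amino shows that it can also fall below the values of both dimethylamino-bearing chains, with a 7.7-fold lower number from compound 1 to compound 4 (0.89 log units; beyond the scatter) and a 9.6-fold lower number from compound 2 to compound 4 (0.98 log units; beyond the scatter) both on record. The step of an 87-fold lower number from compound 3 to compound 4 (1.94 log units; beyond the scatter) is therefore more than a return from the bis-nitrile group to the level of compound 1 and compound 2. Nothing measured here accounts for the size of these steps.

Compound 4 changes the carboxylic acid, the branched chain and the two defined stereocentres together, so their separate shares remain unresolved. Going by these compounds, whether a methyl ester in place of the carboxylic acid, or an unbranched chain ending in a carboxylic acid, would hold the number of compound 4 remains open.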